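A few compounds are considered here, and "the series" means these few. Any claim that something is new, unique, unknown or untested is made for them only; others in the source may bear on it.

Three thiosemicarbazones have been tested in a functional assay on MIA PaCa-2 cells (Homo sapiens) for antiproliferative activity, read by MTT assay, with a stated time of 72 h; on this read-out lower numbers stand for stronger inhibition and higher numbers for weaker inhibition. Compound 1 `Oc1ccc2ccccc2c1/C=N/NC(=S)Nc1ccccc1` gives 600 nM in this assay. Compound 2 `COc1cccc(/C=N/NC(=S)Nc2ccccc2)c1O` gives 2500 nM, which is the higher of the two numbers recorded, and its nearest neighbour is compound 1 with a number that is lower by a margin beyond the usual scatter of repeated measurements. Compound 3 `CCN(CC)c1ccc(/C=N/NC(N)=S)c(O)c1` gives only a limit of the assay, > 5000 nM, rather than a number.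

Compound 4 `Oc1ccccc1/C=N/NC(=S)Nc1ccccc1` has not yet been measured. It differs from compound 2 in one place: hydrogen in place of methoxy on an aromatic carbon. Going by the values given here, no measured pair shows what this particular exchange does, so the size of the step in this assay cannot be read from the data; a small step in either direction, or none beyond the scatter, is the plainest expectation.

Compound 4 is therefore expected to land near its parent, at an estimated 2000 nM with a range of 700 nM to 6000 nM. The expected step from compound 2 to compound 4 is a 1.3-fold lower number from compound 2 to compound 4 (0.10 log units; within the scatter).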

Compound 4, half-maximal inhibitory concentration: 2400 nM
Estimate against measurement, compound 4: 1.2-fold (0.08 log units) below; the measured number falls inside the stated range.
By their numbers in this assay, from the lowest: compound 1; then compounds 4 and 2 (each within the scatter of the next). At a limit, above all of these: compound 3.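

In this assay, hydrogen in place of methoxy on this aromatic carbon, ortho to a hydroxy group, gives a 1.0-fold lower number from compound 2 to compound 4 (0.02 log units; within the scatter). Going by these compounds alone, this is the first direct reading of this position: the methoxy group is not needed there for the antiproliferative activity seen with compound 2, and this exchange alone leaves the number unchanged within the scatter. Nothing measured here explains why the exchange makes so little difference.

Hydrogen and methoxy are the only groups shown at this position, so it remains open what an amine, a chlorine atom or a longer ether chain would do there. On these data alone, it is also open whether the same exchange would make as little difference on the core of compound 1.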